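A larger saturated amine ring at the end of the chain

This account rests on a few compounds, and the source may have more. Where it says the series, first, only, none or still open, it means among the compounds named here.

In a functional assay on HT-29 cells (Homo sapiens) for cytotoxicity, read by MTT assay, with a stated time of 72 h (a higher number here means a weaker inhibitor, a lower number a stronger inhibitor), compound 2 `COc1cc2c(Oc3ccc(NC(=O)c4nn(-c5ccc(Br)cc5)c(=O)c5ccccc45)cc3F)ccnc2cc1OCCCN1CCCC1` gives 670 nM, the lowest of the three numbers, though compound 1 `COc1cc2c(Oc3ccc(NC(=O)c4nn(-c5ccccc5)c(=O)c5ccccc45)cc3F)ccnc2cc1OCCCN1CCCC1` at 980 nM sits within the scatter of it (a 1.5-fold lower number from compound 1 to compound 2 (0.17 log units; within the scatter)). Compound 3 `COc1ccc(-n2nc(C(=O)Nc3ccc(Oc4ccnc5cc(OCCCN6CCCC6)c(OC)cc45)c(F)c3)c3ccccc3c2=O)cc1` gives 2360 nM; the steps of a 2.4-fold higher number from compound 1 to compound 3 (0.38 log units; beyond the scatter) and a 3.5-fold higher number from compound 2 to compound 3 (0.55 log units; beyond the scatter) are modest and beyond the scatter. Compound 4 `COc1cc2c(Oc3ccc(NC(=O)c4nn(-c5ccc(Br)cc5)c(=O)c5ccccc45)cc3F)ccnc2cc1OCCCN1CCC(C)CC1` differs from compound 2 in one place: 4-methylpiperidin-1-yl in place of pyrrolidin-1-yl on a saturated chain carbon, three bonds along the chain from an oxygen on an aromatic ring. All three measured steps alter a group on an aromatic carbon elsewhere in the molecule, and none touches this chain, so they offer no direct guide. With nothing to point either way, for compound 4 the step of a 1.0-fold higher number from compound 2 to compound 4 (0.02 log units; within the scatter) is expected to lie within the scatter. The estimate for compound 4 is 700 nM, with a range from 300 nM to 1600 nM.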

Compound 4, half-maximal inhibitory concentration: 920 nM
Compound 4: the middle estimate sits 1.3-fold (0.12 log units) below what was measured; measured number inside the range.
By their numbers in this assay, from the lowest: compounds 2, 4 and 1 (each within the scatter of the next); then compound 3.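

In this assay, this is the only step shown that alters the end of the chain rather than an aromatic carbon. Swapping pyrrolidin-1-yl for the larger 4-methylpiperidin-1-yl leaves the result within the scatter (a 1.4-fold higher number from compound 2 to compound 4 (0.14 log units; within the scatter)), so in this bromo compound the larger ring at the chain end brings no clear change. Nothing measured here offers a reason for this result. Still open, going by these compounds, is whether morpholine or an open-chain amine such as diethylamino at the chain end would behave alike, and whether compound 1 or compound 3 would tolerate 4-methylpiperidin-1-yl equally well.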